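The source may hold more compounds than are shown below. What is called first, only, known or untested is meant among the compounds shown, and "the series" means these compounds.

Measured so far in an ADME assay on isolated protein for inhibition of Dipeptidyl peptidase 9 (Homo sapiens), with stated times of 15 min, 60 s and 20 min; a lower number here means a stronger inhibitor, a higher number a weaker inhibitor:
- compound 1, `CC#CCn1c(N2CCC[C@@H](N)C2)nc2c1c(=O)n(Cc1cc(Cl)ccc1C(=O)O)c(=O)n2C`, gives > 100000 nM, a limit of the assay and not a number.
- compound 2, `CC#CCn1c(N2CCC[C@@H](N)C2)nc2c1c(=O)n(Cc1ccc(Br)cc1C(=O)OCC)c(=O)n2C`, gives > 100000 nM, again a limit.
- compound 3, `CC#CCn1c(N2CCC[C@@H](N)C2)nc2c1c(=O)n(Cc1c(Br)cccc1C(=O)O)c(=O)n2C`, gives > 100000 nM, also a limit.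

Compound 3 thus stands only at a limit in this assay, and the two further values shown are limits as well. The steps a step that the two limits leave unreadable from compound 1 to compound 2, a step that the two limits leave unreadable from compound 1 to compound 3 and a step that the two limits leave unreadable from compound 2 to compound 3 are unreadable in size, since every value involved sits at the limit of > 100000 nM in this assay, at which 3 of the 3 values shown sit.

Compound 4, `CC#CCn1c(N2CCC[C@@H](N)C2)nc2c1c(=O)n(Cc1ccc(F)cc1C(=O)O)c(=O)n2C`, is not yet measured. Its difference from compound 3: 2-carboxy-4-fluorophenyl in place of 2-bromo-6-carboxyphenyl on a saturated chain carbon bound to an aromatic nitrogen. For the measured compounds named here, the three measured steps bear on it only in that each variation so far of the group on the saturated chain carbon bound to an aromatic nitrogen has stayed at the limit; no direction or size can be read from them. Compound 4 is expected to stay at the limit as well, so the expected step that the limit leaves unreadable from compound 3 to compound 4 carries no readable meaning. The estimate for compound 4 is 200000 nM, range 100000 nM to 1000000 nM.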

Compound 4, half-maximal inhibitory concentration: > 100000 nM
Compound 4: no number, only a limit; the forecaster's own chance of this, stated with the estimate: 85%; the middle value lies beyond the limit too.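

No new step can be read: compound 1, compound 2, compound 3 and compound 4 share one limit, so the steps joining compound 4 to the others stay unreadable in size: the limit of > 100000 nM in this assay, at which 4 of the 4 values shown sit.

On these data alone, whether any group on the saturated chain carbon bound to an aromatic nitrogen gives a number in this assay instead of a limit stays open.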